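Trifluoromethyl for fluoro on a limit-bound aryl ether

The compounds below may be only part of what the source reports. "The series", "measured", "known", "first", "only" and "open" are said of these compounds alone.

Measured compounds:
compound 1, `Cc1nnsc1CO/N=C/c1c(C)nn(C)c1Oc1ccccc1Cl`: > 50000 nM
compound 2, `Cc1nnsc1CO/N=C/c1c(C)nn(C)c1Oc1cccc(F)c1`: > 50000 nM

In a functional assay on Huh-7 cells (Homo sapiens) for inhibition, read by MTT assay, with a stated time of 48 h (on this read-out lower numbers stand for stronger inhibition and higher numbers for weaker inhibition), compound 1 gives > 50000 nM, which is a limit of the assay and not a number. Compound 2 gives > 50000 nM in this assay, again only a limit. For the measured compounds named here, the one measured step, a step that the two limits leave unreadable from compound 1 to compound 2, is therefore unreadable. Compound 2 thus stands where every value shown stands, at the limit of > 50000 nM in this assay, at which 2 of the 2 values shown sit, with no number beneath it.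

Compound 3, `Cc1nnsc1CO/N=C/c1c(C)nn(C)c1Oc1cccc(C(F)(F)F)c1`, differs from compound 2 by trifluoromethyl in place of fluoro on an aromatic carbon. Going by the values given here, no measured step bears on this change, and the only step available is itself unreadable. The expectation for compound 3 can rest only on compound 2 sitting at the limit in this assay: compound 3 is expected to give 50000 nM, with a range from 15000 nM to 100000 nM, and most likely to be reported as a limit once more. The expected step is a number no higher from compound 2 to compound 3 (the limit leaves the size open), nothing beyond the scatter.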

Compound 3, half-maximal inhibitory concentration: > 50000 nM
Compound 3 gave a limit, no number (the forecaster's own chance of this, stated with the estimate: 75%); the middle value sits exactly at the limit.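

In this assay, for the compounds shown here, compound 2 and compound 3 each give only a limit, and no step between them can be read. All the values shown sit in one place: the limit of > 50000 nM in this assay, at which 3 of the 3 values shown sit.

The compounds shown leave open whether any change to the aryl ether on the shared core would give a measurable number in this read-out.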